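The source may hold more compounds than are shown below. What is called first, only, known or untested is meant among the compounds shown, and "the series" means these compounds.

Measured so far in an ADME assay on Vero cells (Chlorocebus sabaeus) for cytotoxicity, read by MTT assay, with a stated time of 72 h; on this read-out higher numbers stand for lower toxicity in this test and lower numbers for higher toxicity in this test:
- compound 1 `COc1ccc(/C=C(\C)C(=O)/C=C/c2ccccc2Cl)cc1`: 74300 nM
- compound 2 `COc1ccc(/C=C(\C)C(=O)/C=C/c2cccc(Cl)c2Cl)cc1`: 119000 nM

Among the compounds with values here, with only two numbers available, compound 1 has a single neighbour, and the two sit level: the step is a 1.6-fold higher number from compound 1 to compound 2 (0.20 log units; within the scatter). The next compound to be tested is compound 3 `COc1ccc(/C=C(\C)C(=O)/C=C/c2ccc(Br)cc2)cc1`. Its structural change from compound 1 is 4-bromophenyl in place of 2-chlorophenyl on a double-bonded chain carbon bound to a double-bonded chain carbon.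

Within the data shown here, only one measured step bears on this change, and it is an indirect guide. It puts chloro in place of hydrogen on an aromatic carbon, and it stayed small at a 1.6-fold higher number from compound 1 to compound 2 (0.20 log units; within the scatter). Among the measured compounds shown here, no measured compound carries bromine, and no measured step moves a halogen around the ring, so the data cannot show what this particular swap does. For the measured compounds named here, the one change seen on this ring made no clear difference, so there is no basis for expecting a shift in either direction. The expected result is a 1.1-fold higher number from compound 1 to compound 3 (0.06 log units; within the scatter), which means no change beyond the scatter. For compound 3, the estimated value in this assay is 85000 nM, with an expected range from 35000 nM to 200000 nM.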

Compound 3, half-maximal cytotoxic concentration: 31200 nM
Beside the measured number, compound 3's estimate is 2.7-fold (0.44 log units) above it; the measured number lies below the stated range.
By their numbers in this assay, from the lowest: compound 3; then compounds 1 and 2 (each within the scatter of the next).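

In this assay, within the data shown here, 4-bromophenyl in place of 2-chlorophenyl gives the first step at this position that clears the scatter, a 2.4-fold lower number from compound 1 to compound 3 (0.38 log units; beyond the scatter), whereas the earlier step, a 1.6-fold higher number from compound 1 to compound 2 (0.20 log units; within the scatter), did not, so this position can respond to a change in the aromatic group, here towards higher toxicity in this test. The two groups have the same count of heavy atoms, but the halogen and its place on the ring change together, so this single step cannot show which of the two matters. No measurement here explains the shift.

The compounds shown leave open how much of the step belongs to bromine itself and how much to the halogen's place on the ring, a question that a 4-chlorophenyl group on the same chain carbon could help to separate. They also leave open whether a group of a different kind on this ring, such as an amine or a carboxylic acid, would move the number at all, and in which direction.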